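Swapping iodo for benzofuranyl on a shared nucleoside core

The source may report more compounds than this note shows. Statements on the series, on what has been measured and on what is new or still open speak of the compounds shown alone.

Measured compounds:
compound 1, `CNc1ncnc2c1c(I)cn2[C@@H]1O[C@H](CO)[C@@H](O)[C@H]1O`: > 20000 nM
compound 2, `COc1ncnc2c1c(I)cn2[C@@H]1O[C@H](CO)[C@@H](O)[C@H]1O`: 2300 nM

In a functional assay on HL-60 cells (Homo sapiens) for antiproliferative activity, read by XTT assay, with a stated time of 72 h (on this read-out lower numbers stand for stronger inhibition and higher numbers for weaker inhibition), compound 1 reports only a limit, > 20000 nM, so no number is known for it; it sits at the limit of > 20000 nM in this assay, at which 1 of the 2 values shown sits. Compound 2 gives 2300 nM. Going by the values given here, the single measured step, an at least 8.6-fold lower number from compound 1 to compound 2 (0.93 log units; beyond the scatter), alters a different part of the core, so it does not bear on the change followed here. Compound 3, `CNc1ncnc2c1c(-c1cc3ccccc3o1)cn2[C@@H]1O[C@H](CO)[C@@H](O)[C@H]1O`, differs from compound 1 by 1-benzofuran-2-yl in place of iodo on an aromatic carbon. Among the compounds with values here, with no measured step to guide this change, no direction beyond the scatter is expected. Compound 3 is estimated at 10000 nM, between 2000 nM and 50000 nM. That estimate corresponds to an expected step of an at least 2.0-fold lower number from compound 1 to compound 3 (0.30 log units; that floor lies within the scatter).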

Compound 3, half-maximal inhibitory concentration: 8950 nM
Beside the measured number, compound 3's estimate is 1.1-fold (0.05 log units) above it, within the range that was stated.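

Putting 1-benzofuran-2-yl in place of iodo on this aromatic carbon gives an at least 2.2-fold lower number from compound 1 to compound 3 (0.34 log units; beyond the scatter), the first step shown at this position. So this carbon can carry a group of two fused aromatic rings, and compound 3 gives a real number where compound 1 does not. The size of the step remains unknown, however, because compound 1 stands only at a limit: the limit of > 20000 nM in this assay, at which 1 of the 3 values shown sits.

Going by these compounds, how a phenyl group or an amine on this carbon would compare remains open. So does whether 1-benzofuran-2-yl would also lower the number for compound 2, which carries methoxy in place of methylamino.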